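Trimethoxy versus dimethoxy in a pyrazolyl chalcone series

This account rests on a few compounds, and the source may have more. Where it says the series, first, only, none or still open, it means among the compounds named here.

Of the compounds shown here, three have been measured. Compound 1 `COc1ccc(-c2cc(/C=C/C(=O)c3ccc(N)cc3)[nH]n2)cc1` gives 5% in a functional assay on SNB-19 cells (Homo sapiens) for cytotoxicity, read by sulforhodamine B assay, with a stated time of 48 h, tested at 10 uM; a lower number here means a stronger effect, a higher number a weaker effect of the compound at the concentration tested. Compound 2 `COc1ccc(-c2cc(/C=C/C(=O)c3ccc(N)cc3)[nH]n2)cc1OC` gives 31% in this assay. The two differ by hydrogen in place of methoxy on an aromatic carbon, and the step of a number 26 percentage points lower from compound 2 to compound 1 (beyond the scatter). Compound 3 `COc1cc(C(=O)/C=C/c2cc(-c3cc(OC)c(OC)c(OC)c3)n[nH]2)cc(OC)c1OC` gives -62% in this assay, the lowest of the three numbers; the difference between its core and the core of compound 2 is not broken down here, and only the two values are compared.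

Compound 4 `COc1ccc(-c2cc(/C=C/C(=O)c3cc(OC)c(OC)c(OC)c3)[nH]n2)cc1OC` has not yet been measured. It differs from compound 3 by hydrogen in place of methoxy on an aromatic carbon, the same kind of change as that from compound 2 to compound 1, though in compound 3 the place is additionally meta to a methoxy group. From compound 3 to compound 4 a small step is expected, a number 12 percentage points higher from compound 3 to compound 4 (beyond the scatter), resting on the modest step of a number 26 percentage points lower from compound 2 to compound 1 (beyond the scatter) and on compound 3 already standing at -62%. Compound 4 is therefore estimated at -50% in this assay, most likely between -85% and -10%.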

Compound 4, a percentage reported as activity, at one concentration (the size of the read-out at that concentration, not a potency): -29%
Compound 4: middle estimate off by 21 percentage points, on the low side, and the stated range covers the measured number.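

On the core of compound 3, replacing a methoxy group with hydrogen gives a number 33 percentage points higher from compound 3 to compound 4 (beyond the scatter) in this assay, whereas the same kind of change on the core of compound 2 gives a number 26 percentage points lower from compound 2 to compound 1 (beyond the scatter). The change therefore does not carry from one core to the other, in either size or direction, within this series: the same change on two cores in this assay, a number 26 percentage points lower (beyond the scatter) from compound 2 to compound 1 and a number 33 percentage points higher (beyond the scatter) from compound 3 to compound 4, 59 percentage points apart, beyond the scatter of two such steps. Within the data shown here, with only one pair on each core, this shows that the outcome of the exchange depends on its setting, but it does not show which difference between the two cores is responsible, nor does it give any rule for predicting the step on a further core.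

The compounds shown leave open how the same exchange would behave on a third core, and whether a hydroxyl group or a chlorine atom in that place would follow either step. They also leave open how these steps would look at other concentrations, as each compound is represented here by a single read-out.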